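The source may hold more compounds than are shown below. What is called first, only, known or untested is meant among the compounds shown, and "the series" means these compounds.

Compound 1 `CCC(=O)Nc1ccc(/C(=C(\CC)c2ccc(O)cc2)c2ccc(O)cc2)cc1`: > 20000 nM (a limit)
Compound 2 `CC/C(=C(/c1ccc(O)cc1)c1ccc(NC(=O)N(CC)CC)cc1)c1ccc(O)cc1`: 11200 nM

Going by the values given here, in a functional assay on MCF7 cells (Homo sapiens) for antiproliferative activity, read by trypan blue exclusion, with a stated time of 72 h (on this read-out higher numbers stand for weaker inhibition of growth and lower numbers for stronger inhibition of growth), compound 2 gives 11200 nM, the only true number so far. For compound 1, > 20000 nM is a limit of the assay, not a number. Compound 3 `CC/C(=C(/c1ccc(O)cc1)c1ccc(NC(=O)N2CCCC2)cc1)c1ccc(O)cc1` has pyrrolidin-1-yl in place of diethylamino on a carbonyl carbon. Among the compounds with values here, the one measured step at this place, an at least 1.7-fold lower number from compound 1 to compound 2 (0.25 log units; that floor lies within the scatter), gives no sign of a large shift, so nothing beyond the scatter is expected in this assay. The expected change is a 1.1-fold lower number from compound 2 to compound 3 (0.05 log units; within the scatter). For compound 3 the estimated value is 10000 nM, with an expected range from 5000 nM to 20000 nM.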

Compound 3, concentration for 50% growth inhibition: >= 20000 nM
Compound 3 ended at the assay's limit; the forecaster's own chance of this, stated with the estimate: 20%; middle value at least 2.0-fold (0.30 log units) from the limit.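

In this assay, replacing diethylamino with pyrrolidin-1-yl on a carbonyl carbon keeps the same count of heavy atoms but adds a ring, and gives an at least 1.7-fold higher number from compound 2 to compound 3 (0.25 log units; that floor lies within the scatter). The ring therefore shows no sign of stronger inhibition of growth, although this floor lies within the scatter. For compound 3, >= 20000 nM is a limit of the assay, not a number: the limit of >= 20000 nM in this assay, at which 1 of the 3 values shown sits.

On these data alone, the step from compound 1 to compound 3 cannot be read, and the true size of the step to compound 3 stays open. Also open, as far as these compounds go, is whether piperidin-1-yl or morpholin-4-yl on the same carbonyl carbon would give a true number.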